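The source may hold more compounds than are shown below. What is called first, only, known or untested is meant among the compounds shown, and "the series" means these compounds.

Compound 1 `COC(=O)C[C@H](NC(=O)OC(C)(C)C)C(=O)N(Cc1ccc(F)cc1)C1(C(=O)NCc2ccccc2)CCN(Cc2ccccc2)CC1` — > 100000 nM
Compound 2 `COC(=O)C[C@H](NC(=O)OC(C)(C)C)C(=O)N(Cc1ccc(F)cc1)C1(C(=O)NC2CCCCC2)CCN(Cc2ccccc2)CC1` — 100000 nM
Compound 3 `COC(=O)C[C@H](NC(=O)OC(C)(C)C)C(=O)N(Cc1ccc(F)cc1)C1(C(=O)NCS(=O)(=O)c2ccc(C)cc2)CCN(Cc2ccccc2)CC1` — 4000 nM

In an ADME assay on MDCK cells (Canis lupus familiaris) for cytotoxicity, read by microscopy, with a stated time of 72 h (a higher number here means that more compound is tolerated, a lower number that less compound is tolerated), compound 1 gives > 100000 nM, which is a limit of the assay rather than a number (the limit of > 100000 nM in this assay, at which 1 of the 3 values shown sits). Compound 2 gives 100000 nM, and compound 3 gives 4000 nM. The step from compound 1 to compound 3 an at least 25-fold lower number from compound 1 to compound 3 (1.39 log units; beyond the scatter) and the step from compound 2 to compound 3 a 25-fold lower number from compound 2 to compound 3 (1.40 log units; beyond the scatter) are large, while the step from compound 1 to compound 2 a number no higher from compound 1 to compound 2 (the limit leaves the size open) leaves its size open. Compound 4 `COC(=O)C[C@H](NC(=O)OC(C)(C)C)C(=O)N(Cc1ccc([N+](=O)[O-])cc1)C1(C(=O)NCc2ccccc2)CCN(Cc2ccccc2)CC1` differs from compound 1 in nitro in place of fluoro on an aromatic carbon. Among the compounds with values here, none of the measured steps touches this position, so no step bears on it directly. Compound 4 is therefore expected to give 100000 nM, between 30000 nM and 100000 nM. The expected step of a number no higher from compound 1 to compound 4 (the limit leaves the size open) is estimated to lie within the scatter.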

Compound 4, minimum cytotoxic concentration: 20000 nM
Estimate against measurement, compound 4: 5.0-fold (0.70 log units) above, and the stated range ends above it.
By their numbers in this assay, from the lowest: compound 3; then compound 4; then compound 2.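

In this assay, within the data shown here, the 4-fluorobenzyl group proves able to shift the number, which the earlier compounds, all sharing it, could not show: nitro in place of fluoro on an aromatic carbon gives an at least 5.0-fold lower number from compound 1 to compound 4 (0.69 log units; beyond the scatter). The earlier large steps came only from changes at the amide-type nitrogen, whereas compound 4 keeps the benzyl there. Compound 1 stands at a limit of the assay, and the full size of the step stays open: the limit of > 100000 nM in this assay, at which 1 of the 4 values shown sits.

From the compounds shown here alone, whether an amine or a carboxylic acid at this place would give a similar number stays open. So does whether this change would act alike with the cyclohexyl of compound 2.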